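The source may hold more compounds than are shown below. What is called first, only, known or untested is meant among the compounds shown, and "the series" means these compounds.

Working notes on the series. In a functional assay on HepG2 cells (Homo sapiens) for antiproliferative activity, read by MTT assay, with a stated time of 72 h (on this read-out higher numbers stand for weaker inhibition and lower numbers for stronger inhibition), compound 1 `COc1cccc(N2C(=O)COc3ccc(-c4cnc5ccccc5c4)cc32)c1` gives 2080 nM, the lowest number among the measured compounds. Compound 3 `COc1cccc(N2C(=O)COc3ccc(-c4ccc(O)cc4)cc32)c1` gives 26100 nM, a higher number by a margin beyond the scatter. Compound 2 `O=C1COc2ccc(-c3cnc(Cl)c(NS(=O)(=O)c4ccc(F)cc4)c3)cc2N1c1ccc(F)cc1` returns only a limit of the assay, > 40000 nM, and not a number.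

The step to follow leads to compound 4 `COc1ccc(N2C(=O)COc3ccc(-c4cnc5ccccc5c4)cc32)cc1`, which carries 4-methoxyphenyl in place of 3-methoxyphenyl on an amide-type nitrogen in a ring. The two share the same atoms, joined differently. Among the compounds with values here, no two measured compounds differ in one place only, so the series offers no measured step to set the size of this one. The expectation therefore rests on the structural change itself and on compound 1 at 2080 nM as the sole anchor. The expected result in this assay is a 1.4-fold higher number from compound 1 to compound 4 (0.16 log units; within the scatter), a small move toward a higher number that is expected to stay within the scatter, though the uncertainty is wide. Compound 4 is estimated at 3000 nM, with an expected range from 800 nM to 12000 nM in this assay.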

Compound 4, half-maximal inhibitory concentration: > 40000 nM
Compound 4: no number, only a limit; the forecaster's own chance of this, stated with the estimate: 3%; middle value at least 13-fold (1.12 log units) from the limit.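

In this assay, 4-methoxyphenyl in place of 3-methoxyphenyl on the amide-type nitrogen in a ring gives an at least 19-fold higher number from compound 1 to compound 4 (1.28 log units; beyond the scatter). Within the data shown here, this is the first step that changes one place only, and it shows that this position can separate two compounds with the same atoms, joined differently, by a margin beyond the scatter. Compound 4 gives > 40000 nM, which is a limit of the assay and not a number, so the step has a lower bound and no measured upper end: the limit of > 40000 nM in this assay, at which 2 of the 4 values shown sit.

The compounds shown leave open whether an unsubstituted phenyl, or a phenyl carrying an amine or a carboxylic acid in place of the methoxy group, on the same nitrogen would stay close to compound 1 or reach the limit as compound 4 does. They also leave open whether the same exchange on the core of compound 3 would give a step of similar size, so the result holds for this pair alone and cannot yet be read as a general pattern.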